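Para substituent swap on the shared core

The compounds below may be only part of what the source reports. "The series", "measured", "known", "first", "only" and "open" are said of these compounds alone.

Compound 1 `CCOC(=O)c1c(N)sc(/N=C/c2ccc(N(C)C)cc2)c1C(=O)OCC` is the reference point of the series. Among the compounds with values here, in a functional assay on MCF7 cells (Homo sapiens) for inhibition, read by MTT assay, with a stated time of 48 h (a lower number here means a stronger inhibitor, a higher number a weaker inhibitor), compound 1 gives 5700 nM, the lowest of the three numbers so far; compound 3 `CCOC(=O)c1c(N)sc(/N=C/c2ccc(C)cc2)c1C(=O)OCC` gives 8900 nM, and compound 2 `CCOC(=O)c1c(N)sc(/N=C/c2ccncc2)c1C(=O)OCC` gives 92200 nM. The step of a 1.6-fold higher number from compound 1 to compound 3 (0.19 log units; within the scatter) stays within the scatter, whereas a 16-fold higher number from compound 1 to compound 2 (1.21 log units; beyond the scatter) and a 10-fold lower number from compound 2 to compound 3 (1.02 log units; beyond the scatter) are both large.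

Compound 4 `CCOC(=O)c1c(N)sc(/N=C/c2ccc(Br)cc2)c1C(=O)OCC` differs from compound 1 by bromo in place of dimethylamino on an aromatic carbon. The step that bears on it most directly is a 1.6-fold higher number from compound 1 to compound 3 (0.19 log units; within the scatter), an exchange of the group on the same aromatic carbon that changed little. The large steps of a 16-fold higher number from compound 1 to compound 2 (1.21 log units; beyond the scatter) and a 10-fold lower number from compound 2 to compound 3 (1.02 log units; beyond the scatter) replace the whole ring and do not apply here, since the six-membered aromatic ring of carbon only is kept. The expected step is therefore a 1.4-fold higher number from compound 1 to compound 4 (0.15 log units; within the scatter), most likely within the scatter or at most a modest weakening. Compound 4 is estimated at 8000 nM, with a range from 3000 nM to 25000 nM.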

Compound 4, half-maximal inhibitory concentration: 12500 nM
For compound 4 the middle estimate is 1.6-fold (0.19 log units) below the measured one, within the range that was stated.
By their numbers in this assay, from the lowest: compounds 1, 3 and 4 (each within the scatter of the next, the first and the last beyond it); then compound 2.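

Within the data shown here, on the aromatic carbon para to a large group, bromo in place of dimethylamino gives a 2.2-fold higher number from compound 1 to compound 4 (0.34 log units; beyond the scatter) and is the first exchange there to pass the scatter, though the step is only modest. Bromo and methyl remain within the scatter of each other, with a 1.4-fold higher number from compound 3 to compound 4 (0.15 log units; within the scatter) in this assay, while a 7.4-fold lower number from compound 2 to compound 4 (0.87 log units; beyond the scatter) places the 4-bromophenyl compound with the other two substituted phenyl compounds, well clear of the pyridin-4-yl compound. No measurement at hand accounts for these differences.

Open, on these data alone, is whether a primary amine or a carboxylic acid on this aromatic carbon would stay close to compound 1, compound 3 and compound 4 or move towards compound 2. Also open, as far as these compounds go, is whether a pyridin-3-yl ring would differ from pyridin-4-yl.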